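The step from compound 3 to compound 4

A few compounds are considered here, and "the series" means these few. Any claim that something is new, unique, unknown or untested is made for them only; others in the source may bear on it.

Compound 1 `O=C(O)C12CCC(C(=O)N3CC[C@](c4ccc(C(F)(C(F)(F)F)C(F)(F)F)cc4)(S(=O)(=O)c4ccc(F)cc4)C3)(CC1)C2` in an ADME assay on microsomes from liver (Homo sapiens) for metabolic stability, with a stated time of 10 min (a higher number here means that more of the compound is left, a lower number that less of the compound is left), gives "not determined" (no result reported)
Compound 2 `O=C(O)C12CCC(C(=O)N3CC[C@](c4ccc(C(F)(C(F)(F)F)C(F)(F)F)cc4)(S(=O)(=O)c4ccc(F)cc4)C3)(CC1)OC2` in this assay gives 90%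
Compound 3 `O=C(N1CC[C@](c2ccc(C(F)(C(F)(F)F)C(F)(F)F)cc2)(S(=O)(=O)c2ccc(F)cc2)C1)C12CCC(C(=O)O)(CC1)OC2` in this assay gives "not determined" (no result reported)

Going by these compounds, compound 3 has no single number here, so its standing is unknown, and compound 2 supplies the only figure. Compound 4 `O=C([C@H]1CC[C@H](c2nnn[nH]2)CC1)N1CC[C@](c2ccc(C(F)(C(F)(F)F)C(F)(F)F)cc2)(S(=O)(=O)c2ccc(F)cc2)C1` has yet to be measured. The structural change is a group of 11 heavy atoms (7 carbon, 4 nitrogen; one five-membered aromatic ring with 4 hetero atoms, one six-membered non-aromatic ring of carbon only) in place of a group of 11 heavy atoms (8 carbon, 3 oxygen; one six-membered non-aromatic ring of carbon only, one six-membered non-aromatic ring with 1 hetero atom), on a carbonyl carbon, bringing in 4-(1H-tetrazol-5-yl)cyclohexyl on a carbonyl carbon. Among the measured compounds shown here, no measured step is available to gauge this change in this assay. Relative to compound 2 at 90%, a small downward step is expected, perhaps none beyond the scatter. For compound 4 the estimated value is 80%, with 55% to 97% as the expected range.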

Compound 4, percent of the compound remaining: 100%
For compound 4 the middle estimate is 20 percentage points below the measured one, outside the stated range (above it).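

In this assay, the exchange on the carbonyl carbon gives a number 10 percentage points higher from compound 2 to compound 4 (within the scatter). Among the compounds shown here, this shows that 4-(1H-tetrazol-5-yl)cyclohexyl can take the place of the group in compound 2 with no difference beyond the scatter, which the earlier compounds alone could not show. Nothing available explains this result.

Steps involving compound 1 or compound 3 cannot be read, so the group in compound 3 remains unplaced. Going by these compounds, it also remains open how a cyclohexyl carrying an amine in place of the tetrazole would behave at this carbonyl carbon.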